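A few compounds are considered here, and "the series" means these few. Any claim that something is new, unique, unknown or untested is made for them only; others in the source may bear on it.

Compound 1 `COc1ccc(NC(=O)c2cccc(/C=C3\CC(=O)N(c4ccccc4)C3=O)c2)c(C)c1`: in an ADME assay on NCM460 cells (Homo sapiens) for cytotoxicity, read by MTT assay, with a stated time of 72 h (a higher number here means a weaker inhibitor, a lower number a stronger inhibitor), compound 1 gives > 100000 nM, a limit of the assay rather than a number.
Compound 2 `CCc1cccc(NC(=O)c2cccc(/C=C3\CC(=O)N(c4ccccc4)C3=O)c2)c1`: in this assay compound 2 gives > 100000 nM, again a limit.
Compound 3 `COc1ccc(OC)c(NC(=O)c2cccc(/C=C3\CC(=O)N(c4ccccc4)C3=O)c2)c1`: in this assay compound 3 gives > 100000 nM, also a limit.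

Compound 3 therefore stands where every measured compound stands: at the limit of the assay, with no number beneath it, and the same holds for the other two values shown (the limit of > 100000 nM in this assay, at which 3 of the 3 values shown sit). The steps that join the measured compounds, a step that the two limits leave unreadable from compound 1 to compound 2, a step that the two limits leave unreadable from compound 1 to compound 3 and a step that the two limits leave unreadable from compound 2 to compound 3, are all unreadable, since both ends of each sit at a limit; none of them tells whether exchanging one aryl group on the amide-type nitrogen for another moves cytotoxicity at all.

The compound not yet measured is compound 4 `Cc1ccc(NC(=O)c2cccc(/C=C3\CC(=O)N(c4ccccc4)C3=O)c2)cc1`. It differs from compound 3 by 4-methylphenyl in place of 2,5-dimethoxyphenyl on an amide-type nitrogen. Among the compounds with values here, the steps that bear on this change are the three above, and none carries a readable size, so no direction can be drawn from them; the only evidence is that every such aryl exchange so far has left the value at the limit (the limit of > 100000 nM in this assay, at which 3 of the 3 values shown sit). Compound 4 is accordingly expected to give 150000 nM, within 50000 nM to 500000 nM, which is the expected step that the limit leaves unreadable from compound 3 to compound 4, most probably reported again as a limit.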

Compound 4, half-maximal inhibitory concentration: > 100000 nM
Compound 4: no number, only a limit (the forecaster's own chance of this, stated with the estimate: 85%); the middle value is on the limit's open side.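

In this assay compound 4 gives > 100000 nM as a limit of the assay. Its steps from compound 1, compound 2 and compound 3 therefore cannot be read: the limit of > 100000 nM in this assay, at which 4 of the 4 values shown sit. The compounds shown leave open whether exchanging the aryl group on the amide-type nitrogen changes cytotoxicity at all, and at what concentration any of them would reach half-maximal inhibition.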